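Sulfonyl aryl variation and liver microsomal clearance

The compounds below may be only part of what the source reports. "The series", "measured", "known", "first", "only" and "open" are said of these compounds alone.

Measured so far:
- compound 1 `O=S(=O)(c1ccc(F)cc1)c1cnc2cc(F)ccc2c1-c1cccc(F)c1` gives 0.95 mL/min in an ADME assay on microsomes from liver (Homo sapiens) for metabolic stability, tested at 2.5 uM; a higher number here means faster removal of the compound, a lower number slower removal
- compound 2 `COc1cccc(S(=O)(=O)c2cnc3cc(F)ccc3c2-c2cccc(F)c2)c1` gives 3.36 mL/min in this assay
- compound 3 `O=S(=O)(c1cc(Cl)cc(Cl)c1)c1cnc2cc(F)ccc2c1-c1cccc(F)c1` gives 0.41 mL/min in this assay

The three measured compounds share one core and differ only in the aryl group on the sulfonyl sulfur. Compound 3 stands lowest of the three in this assay; the nearest value is that of compound 1 and the farthest that of compound 2. The steps run as follows: a 2.3-fold lower number from compound 1 to compound 3 (0.36 log units; beyond the scatter), an 8.2-fold lower number from compound 2 to compound 3 (0.91 log units; beyond the scatter) and a 3.5-fold higher number from compound 1 to compound 2 (0.55 log units; beyond the scatter).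

Compound 4 `O=S(=O)(c1cccc(F)c1)c1cnc2cc(F)ccc2c1-c1cccc(F)c1` is not yet measured. The change from compound 3 is 3-fluorophenyl in place of 3,5-dichlorophenyl on a sulfonyl sulfur. The step that bears on it most directly is a 2.3-fold lower number from compound 1 to compound 3 (0.36 log units; beyond the scatter), which runs in the opposite sense: compound 4 again carries a single fluorine on the aryl group, as compound 1 does, though as 3-fluorophenyl rather than 4-fluorophenyl. Among the measured compounds shown here, no measured pair separates those two aryl groups, so the expectation rests on compound 1 and its value 0.95 mL/min. A modest rise in this assay is therefore expected, about a 2.2-fold higher number from compound 3 to compound 4 (0.34 log units; beyond the scatter). For compound 4 the estimate is 0.9 mL/min, with a range of 0.45 mL/min to 1.9 mL/min.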

Compound 4, intrinsic clearance in a liver preparation (reported as CLH), per the amount of preparation that the assay uses: 0.24 mL/min
The estimate for compound 4 lay 3.8-fold (0.57 log units) above the measured number, outside the stated range (below it).
By their numbers in this assay, from the lowest: compounds 4 and 3 (each within the scatter of the next); then compound 1; then compound 2.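

Among the compounds shown here, the step of a 4.0-fold lower number from compound 1 to compound 4 (0.60 log units; beyond the scatter) in this assay is the first direct comparison of two aryl groups that each carry a single fluorine, and it shows that 3-fluorophenyl and 4-fluorophenyl on a sulfonyl sulfur are not interchangeable here. The step of a 1.7-fold lower number from compound 3 to compound 4 (0.23 log units; within the scatter) stays within the scatter, so 3-fluorophenyl and 3,5-dichlorophenyl cannot be told apart at this position in this read-out, even though one carries fluorine and the other two chlorines. For the compounds shown here, the step of a 14-fold lower number from compound 2 to compound 4 (1.15 log units; beyond the scatter), fluoro in place of methoxy on an aromatic carbon, is the widest so far, and it sets the methoxy compound clearly apart from compound 4.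

Nothing given here explains why these aryl groups differ in this read-out. As far as these compounds go, it also remains open whether the gap between 3-fluorophenyl and 4-fluorophenyl holds on any other core, and how an aryl group bearing an amine or a carboxylic acid, or an ethoxy group in place of methoxy, would compare with compound 2 and compound 4.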